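Compound 3 to compound 4: changing the hydroxyl-bearing arm

The source may report more compounds than this note shows. Statements on the series, on what has been measured and on what is new or still open speak of the compounds shown alone.

For the measured compounds named here, in a functional assay on HCT-116 cells (Homo sapiens) for antiproliferative activity, read by MTT assay, with a stated time of 48 h (a lower number here means a stronger inhibitor, a higher number a weaker inhibitor), compound 3 (`CCCCCCCCC(CCO)n1cnc2c(Cl)ncnc21`) reads 1650 nM and holds the lowest of the three numbers so far. Compound 1 (`C=C(CO)C(CCCCCC)n1cnc2c(Cl)ncnc21`) gives 30200 nM and compound 2 (`C=C(CO)C(CCCCCCC)n1cnc2c(Cl)ncnc21`) gives 22400 nM and both stand above compound 3 by more than the scatter.

The step to compound 4 (`C=C(CO)C(CCCCCCCC)n1cnc2c(Cl)ncnc21`) is 1-(hydroxymethyl)ethenyl in place of 2-hydroxyethyl on a saturated chain carbon bound to an aromatic nitrogen and a saturated chain carbon and, in words, 1-(hydroxymethyl)ethenyl replaces 2-hydroxyethyl on a saturated chain carbon bound to an aromatic nitrogen and a saturated chain carbon.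

Compound 1 and compound 2 already carry the entering group, which makes them the closest guides. Going by the values given here, the only measured step is a 1.3-fold lower number from compound 1 to compound 2 (0.13 log units; within the scatter) and it stays within the scatter, so it argues for little movement among compounds with this group. Among the compounds with values here, no measured pair isolates the exchange itself, and compound 3 is the sole example with 2-hydroxyethyl, so the expectation rests on the values alone. Compound 4 should therefore fall near compound 2 at 22400 nM and lose most of the advantage seen for compound 3. The expected change is a 10-fold higher number from compound 3 to compound 4 (1.01 log units; beyond the scatter) and it points to a higher number, beyond the scatter. The estimate for compound 4 is 17000 nM with 6000 nM to 40000 nM as the expected range.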

Compound 4, half-maximal inhibitory concentration: 19400 nM
For compound 4 the middle estimate is 1.1-fold (0.06 log units) below the measured one; low and high end bracket the measured number.
By their numbers in this assay, from the lowest: compound 3; then compounds 4, 2 and 1 (each within the scatter of the next).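

In this assay the exchange of 2-hydroxyethyl for 1-(hydroxymethyl)ethenyl on the saturated chain carbon bound to an aromatic nitrogen and a saturated chain carbon can now be read directly, on an otherwise unchanged compound: the step is large (a 12-fold higher number from compound 3 to compound 4 (1.07 log units; beyond the scatter)) and lies beyond the scatter. For the compounds shown here, the gap between compound 3 and the earlier compounds therefore survives in a pair that differs in this one place. Among the compounds carrying 1-(hydroxymethyl)ethenyl, chain length still does not separate the values (a 1.2-fold lower number from compound 2 to compound 4 (0.06 log units; within the scatter); a 1.6-fold lower number from compound 1 to compound 4 (0.19 log units; within the scatter)), as both steps lie within the scatter, so in this small set the arm matters far more than the chain. Nothing shown here accounts for the size of the arm effect.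

Going by these compounds alone, open is whether 2-hydroxyethyl gives the same large step on the shorter chains of compound 1 and compound 2, as compound 3 remains its only example. Also open is how an amine or a carboxylic acid in place of the hydroxyl, or a chain longer than that of compound 4, would read in this assay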